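Methyl on the amide nitrogen of compound 3

The source may hold more compounds than are shown below. What is called first, only, known or untested is meant among the compounds shown, and "the series" means these compounds.

compound 1 `COc1ccc(-c2nc3cccnc3n2CC(=O)N(C)C)cc1` gives 39.5 mg/kg
compound 2 `CN(C)C(=O)Cn1c(-c2ccsc2)nc2cccnc21` gives 38 mg/kg
compound 3 `CCCNC(=O)Cn1c(-c2ccc(Cl)cc2)nc2cccnc21` gives 37.5 mg/kg

In a functional assay on the whole organism with Mus musculus as the target (a lower number here means that less compound is needed, a higher number that more compound is needed for the effect), compound 3 at 37.5 mg/kg stands within the scatter of both other compounds, so no order can be read among the three. Compound 4 `CCCN(C)C(=O)Cn1c(-c2ccc(Cl)cc2)nc2cccnc21` carries methyl in place of hydrogen on an amide-type nitrogen, turning propylcarbamoyl to methyl(propyl)carbamoyl. For the measured compounds named here, no measured pair isolates this change. Compound 1 at 39.5 mg/kg and compound 2 at 38 mg/kg also lack the amide hydrogen, yet both lie within the scatter of compound 3, though they differ elsewhere too. No shift beyond the scatter is therefore expected in this assay, and the estimated 1.0-fold higher number from compound 3 to compound 4 (0.01 log units; within the scatter) stays small. For compound 4 the estimate is 38 mg/kg, with an expected range of 20 mg/kg to 70 mg/kg.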

Compound 4, dose for half-maximal effect: 11.6 mg/kg
Compound 4: middle estimate off by 3.3-fold (0.52 log units), on the high side; measured number below the stated range.
By their numbers in this assay, from the lowest: compound 4; then compounds 3, 2 and 1 (each within the scatter of the next).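

In this assay, for the compounds shown here, methyl in place of hydrogen on the amide-type nitrogen gives a 3.2-fold lower number from compound 3 to compound 4 (0.51 log units; beyond the scatter) as the only step that isolates one change, and it lies beyond the scatter. This nitrogen is therefore a position where one added carbon moves the number, which the three earlier compounds, all within the scatter of one another, could not show. No evidence on the reason for this step is available.

On these data alone, whether ethyl or a longer chain in place of this methyl extends the step remains open. Also open, as far as these compounds go, is whether the step holds with a cyclopropyl group in place of propyl.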